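Swapping the nitrile of compound 2 for an ethyl amide

The source may hold more compounds than are shown below. What is called first, only, known or untested is meant among the compounds shown, and "the series" means these compounds.

Compound 1, with structure `COc1ccc2c(c1)OC(c1cc(OC)c(OC)c(OC)c1)C(C(=O)NC(C)C)=C2`, carries an isopropylcarbamoyl group on the double-bonded ring carbon of the shared core. In a functional assay for inhibition of nuclear factor NF-kappa-B complex (Homo sapiens) (on this read-out lower numbers stand for stronger inhibition and higher numbers for weaker inhibition), compound 1 reaches only the limit of the assay, > 50000 nM, not a number. Compound 2, `COc1ccc2c(c1)OC(c1cc(OC)c(OC)c(OC)c1)C(C#N)=C2`, has a cyano group in that place, and in this assay compound 2 gives 3400 nM. Among the measured compounds shown here, that is an at least 14-fold lower number from compound 1 to compound 2 (1.16 log units; beyond the scatter), and among the two values shown compound 2 holds the only number, the other being a limit (the limit of > 50000 nM in this assay, at which 1 of the 2 values shown sits).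

Compound 3, `CCNC(=O)C1=Cc2ccc(OC)cc2OC1c1cc(OC)c(OC)c(OC)c1`, reverses the direction of that exchange: ethylcarbamoyl in place of cyano on a double-bonded ring carbon. For the measured compounds named here, the one measured step that bears on it ran from an amide to the nitrile and was large, so putting an amide back is expected to raise the number again. Compound 3 is therefore estimated at 30000 nM in this assay, between 8000 nM and 100000 nM, a step of an 8.8-fold higher number from compound 2 to compound 3 (0.95 log units; beyond the scatter), with a fair chance that only a limit results.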

Compound 3, half-maximal inhibitory concentration: > 50000 nM
Compound 3: a limit, no number (the forecaster's own chance of this, stated with the estimate: 45%); middle value at least 1.6-fold (0.22 log units) from the limit.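

Compound 3 shows that the loss seen with compound 1 does not belong to the isopropyl group alone: ethylcarbamoyl in place of cyano gives an at least 14-fold higher number from compound 2 to compound 3 (1.16 log units; beyond the scatter) in this assay. On this double-bonded ring carbon, both amides shown now fall short of a measurable number, while the nitrile of compound 2 reaches one, and no compound here goes against that. Compound 1 and compound 3 each stop at a limit, so the step between them cannot be read and the ethyl and isopropyl chains cannot be ranked: the limit of > 50000 nM in this assay, at which 2 of the 3 values shown sit.

From the compounds shown here alone, whether any amide in this place can give a number stays open, for instance the plain carboxamide with only hydrogens on its nitrogen. Also open, going by these compounds, is how a carboxylic acid, a methyl ester or an aminomethyl group would compare with the nitrile of compound 2 on the shared core.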